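Substituent swaps at the amino position: compound 3 to compound 4

The source may hold more compounds than are shown below. What is called first, only, known or untested is meant among the compounds shown, and "the series" means these compounds.

Compound 3 `CCCN(Cc1ccccc1)c1cccc(C(=O)N2CCc3ccc(OS(N)(=O)=O)cc3C2)c1` stands second highest of the three numbers in an assay on HEK293 cells for inhibition of Steryl-sulfatase (Homo sapiens), tested at 1 uM (a higher number here means a stronger effect of the compound at the concentration tested, a lower number a weaker effect), where compound 3 gives 67.4%. Compound 2 `CC(C)CCN(CCC(C)C)c1cccc(C(=O)N2CCc3ccc(OS(N)(=O)=O)cc3C2)c1` gives 75.9% in this assay, and compound 1 `CN(C)CCN(CCN(C)C)c1cccc(C(=O)N2CCc3ccc(OS(N)(=O)=O)cc3C2)c1` gives 17.1%. The next compound is compound 4 `CCN(Cc1ccccn1)c1cccc(C(=O)N2CCc3ccc(OS(N)(=O)=O)cc3C2)c1`, which differs from compound 3 by ethyl((pyridin-2-yl)methyl)amino in place of benzyl(propyl)amino on an aromatic carbon. Earlier exchanges at this position ran from a number 50.3 percentage points higher from compound 1 to compound 3 (beyond the scatter) and a number 58.8 percentage points higher from compound 1 to compound 2 (beyond the scatter) down to a number 8.5 percentage points lower from compound 2 to compound 3 (within the scatter), so they can be either large or negligible. Compound 4 keeps an aromatic ring on the amino nitrogen, as compound 3 does; the expected step is a number 12.4 percentage points lower from compound 3 to compound 4 (beyond the scatter), modestly downward with wide uncertainty. The estimate for compound 4 in this assay is 55%, ranging from 30% to 78%.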

Compound 4, a percentage reported as inhibition, at one concentration (the size of the read-out at that concentration, not a potency): 19.9%
Compound 4: middle estimate off by 35.1 percentage points, on the high side, and the stated range ends above it.
By their numbers in this assay, from the lowest: compounds 1 and 4 (each within the scatter of the next); then compounds 3 and 2 (each within the scatter of the next).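

Keeping an aromatic ring on the amino nitrogen does not by itself preserve the read-out in this assay: ethyl((pyridin-2-yl)methyl)amino gives a number 47.5 percentage points lower from compound 3 to compound 4 (beyond the scatter) and a number 56 percentage points lower from compound 2 to compound 4 (beyond the scatter) while also giving a number 2.8 percentage points higher from compound 1 to compound 4 (within the scatter) and so lands with the bis(2-(dimethylamino)ethyl)amino compound. The exchange alters the ring and the chain together, replacing the carbon-only ring with a ring holding one hetero atom and propyl with ethyl. No measurement here bears on the cause of this loss.

Open, going by these compounds, is how benzyl(ethyl)amino would read, as it pairs the carbon-only ring with the ethyl chain. Propyl((pyridin-2-yl)methyl)amino would test the opposite pairing.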